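Trifluoromethyl for Methyl on the Benzyl Arm

The source may report more compounds than this note shows. Statements on the series, on what has been measured and on what is new or still open speak of the compounds shown alone.

Compound 1, `Cc1cc(-c2ccccc2)n(/C(N)=N/S(=O)(=O)c2cc(C)c(Cl)cc2SCc2ccccc2C(F)(F)F)n1`, gives 25000 nM in a functional assay on HCT-116 cells (Homo sapiens) for cytotoxicity, read by MTT assay, with a stated time of 72 h; a higher number here means a weaker inhibitor, a lower number a stronger inhibitor.
Compound 2, `Cc1cc(-c2ccccc2)n(/C(N)=N/S(=O)(=O)c2cc(C)c(Cl)cc2SCc2ccccc2Cl)n1`, gives 170000 nM.
Compound 3, `Cc1cccc(CSc2cc(Cl)c(C)cc2S(=O)(=O)/N=C(\N)n2nc(C)cc2-c2ccccc2)c1`, gives 34000 nM.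

Compound 3 stands second highest of the three numbers. Its nearest neighbour is compound 1, with a 1.4-fold higher number from compound 1 to compound 3 (0.13 log units; within the scatter), so the two cannot be told apart. Compound 2 is the furthest, with a 5.0-fold lower number from compound 2 to compound 3 (0.70 log units; beyond the scatter).

Compound 4, `Cc1cc(-c2ccccc2)n(/C(N)=N/S(=O)(=O)c2cc(C)c(Cl)cc2SCc2cccc(C(F)(F)F)c2)n1`, differs from compound 3 by trifluoromethyl in place of methyl on an aromatic carbon. Within the data shown here, no measured pair swaps methyl for trifluoromethyl directly. The step that comes closest is a 6.8-fold higher number from compound 1 to compound 2 (0.83 log units; beyond the scatter), where the compound carrying trifluoromethyl has the lower number, but that step concerns chloro, not methyl, and sits at a different position of the ring. The evidence is therefore thin, and a small step to a lower number, or none beyond the scatter, is the most that can be expected.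

Compound 4 is estimated to give 25000 nM, with a range of 10000 nM to 60000 nM. This estimate corresponds to an expected 1.4-fold lower number from compound 3 to compound 4 (0.13 log units; within the scatter).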

Compound 4, half-maximal inhibitory concentration: 19000 nM
Compound 4: the middle estimate sits 1.3-fold (0.12 log units) above what was measured; the measured number falls inside the stated range.
By their numbers in this assay, from the lowest: compounds 4, 1 and 3 (each within the scatter of the next); then compound 2.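

In this assay, the direct exchange of methyl for trifluoromethyl on this aromatic carbon gives a 1.8-fold lower number from compound 3 to compound 4 (0.25 log units; within the scatter), so the 3-methylbenzyl and 3-(trifluoromethyl)benzyl arms cannot be told apart. The placement of trifluoromethyl does not separate the compounds either: going from the 2-(trifluoromethyl)phenyl to the 3-(trifluoromethyl)phenyl arm gives a 1.3-fold lower number from compound 1 to compound 4 (0.12 log units; within the scatter). Compounds 1, 3 and 4 thus form one group within the scatter, and only the 2-chlorophenyl arm of compound 2 stands apart, with an 8.9-fold lower number from compound 2 to compound 4 (0.95 log units; beyond the scatter).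

No measurement at hand accounts for the standing of compound 2. The compounds shown also leave open whether an amine or a carboxylic acid on this ring would move the number beyond the scatter of compounds 1, 3 and 4.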